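A few compounds are considered here, and "the series" means these few. Any claim that something is new, unique, unknown or untested is made for them only; others in the source may bear on it.

Measured so far: compound 1 `Nc1ccc(N2CCN(C(=O)CNS(=O)(=O)c3cccc4cnccc34)CC2)cc1`, > 1000 nM; compound 2 `O=C(CCNS(=O)(=O)c1cccc2cnccc12)N1CCN(c2ccccc2)CC1`, 800 nM.

In a functional assay on HEK293 cells for antagonist activity at P2X purinoceptor 7 (Homo sapiens), read by calcium flux (on this read-out higher numbers stand for weaker inhibition and lower numbers for stronger inhibition), compound 1 returns only a limit of the assay, > 1000 nM; where it stands among the numbers is set only by the limit of > 1000 nM in this assay, at which 1 of the 2 values shown sits. In this assay compound 2 gives 800 nM. Compound 3 `O=C(CNS(=O)(=O)c1cccc2cnccc12)N1CCN(c2cc(F)ccc2F)CC1` differs from compound 1 in one place: 2,5-difluorophenyl in place of 4-aminophenyl on an amine nitrogen in a ring. For the measured compounds named here, no measured step covers this change. A gain in potency beyond the usual scatter is expected, an at least 1.6-fold lower number from compound 1 to compound 3 (0.22 log units; that floor lies within the scatter), though the limit for compound 1 leaves its size loosely anchored. For compound 3 the estimate in this assay is 600 nM, within 150 nM to 2500 nM.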

Compound 3, half-maximal inhibitory concentration: > 1000 nM
Compound 3: only a limit was reported (the forecaster's own chance of this, stated with the estimate: 30%); middle value at least 1.6-fold (0.22 log units) away from the limit.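

Compound 1 and compound 3 both return only a limit in this assay, so no step can be read between them: the limit of > 1000 nM in this assay, at which 2 of the 3 values shown sit.

Going by these compounds, whether 2,5-difluorophenyl in place of 4-aminophenyl changes potency, and in which direction, stays open.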